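Halogen Swap on a Shared Core and Cytotoxicity

This account rests on a few compounds, and the source may have more. Where it says the series, first, only, none or still open, it means among the compounds named here.

Compound 1, `CCc1ccc(-c2nc3c(c(C)nn3-c3ccccc3)c(-c3ccccc3I)c2C#N)cc1`, gives > 20000 nM in an ADME assay on BJ cells (Homo sapiens) for cytotoxicity, with a stated time of 72 h (a lower number here means that less compound is needed, a higher number that more compound is needed for the effect), which is a limit.
Compound 2, `CCc1ccc(-c2nc3c(c(C)nn3-c3ccccc3)c(-c3ccccc3Cl)c2C#N)cc1`, gives > 20000 nM in this assay, which is a limit.
Compound 3, `Cc1nn(-c2ccccc2)c2nc(-c3ccc(Cl)cc3)c(C#N)c(-c3ccccc3O)c12`, gives > 20000 nM in this assay, which is a limit.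

Compound 2 and compound 1 differ by iodo in place of chloro on an aromatic carbon. The step that the two limits leave unreadable from compound 2 to compound 1 cannot be read in size because both values sit at the limit of > 20000 nM in this assay, at which 3 of the 3 values shown sit. The difference between the cores of compound 2 and compound 3 is not broken down here. Compound 4, `Cc1nn(-c2ccccc2)c2nc(-c3ccc(I)cc3)c(C#N)c(-c3ccccc3O)c12`, is not yet measured; it differs from compound 3 by iodo in place of chloro on an aromatic carbon. This is the same kind of change as that between compound 2 and compound 1, but the place differs: ortho to a large group in the measured pair, para to a large group in the new one. The step that the limit leaves unreadable from compound 3 to compound 4 in this assay is expected to be small, which rests on compound 3 sitting at the limit of > 20000 nM in this assay, at which 3 of the 3 values shown sit. Compound 4 is expected to give 30000 nM in this assay, most likely again only a limit.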

Compound 4, half-maximal effective concentration in the BJ assay: 19000 nM
Compound 4: the middle estimate sits 1.6-fold (0.20 log units) above what was measured; the measured number falls inside the stated range.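

In the BJ assay the change from 4-chlorophenyl to 4-iodophenyl gives an at least 1.0-fold lower number from compound 3 to compound 4 (0.02 log units; that floor lies within the scatter) and so does not separate the two compounds, while the step on the core of compound 1 cannot be read, which leaves no size to carry from one core to the other. In the BJ assay compound 3 gives > 20000 nM as a limit. In a physicochemical assay for solubility, read by spectrophotometry, in phosphate buffer, with a stated time of 18 h, at pH 7.4 (a lower number here means a less soluble compound, a higher number a more soluble compound), compound 3 gives 3800 nM and compound 4 gives 1500 nM. On this core the change from chloro to iodo goes with lower solubility in the physicochemical assay, but the compounds shown do not tell whether this carries over to the core of compound 1: the measured solubility of compound 3, 3800 nM, and of compound 4, 1500 nM, a 2.5-fold lower number (0.40 log units; beyond the scatter).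

On these data alone, whether a fluoro group, an amine or a carboxylic acid in place of the iodo would read differently in either assay stays open. Any order among these compounds in cytotoxicity also stays open: the limit of > 20000 nM in the BJ assay, at which 3 of the 4 values shown sit.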